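The source may hold more compounds than are shown below. What is called first, only, known or untested is meant among the compounds shown, and "the series" means these compounds.

Compound 1 `O=C(N/N=C/c1ccccc1)N1CCc2ncnc(Nc3ccc(F)c(Cl)c3)c2C1` gives 28800 nM in a functional assay on NCI-H1975 cells (Homo sapiens) for cytotoxicity, read by MTT assay, with a stated time of 72 h; a higher number here means a weaker inhibitor, a lower number a stronger inhibitor.
Compound 2 `O=C(N/N=C/c1cccc([N+](=O)[O-])c1)N1CCc2ncnc(Nc3ccc(F)c(Cl)c3)c2C1` gives 86900 nM in this assay.
Compound 3 `N#Cc1ccc(/C=N/NC(=O)N2CCc3ncnc(Nc4ccc(F)c(Cl)c4)c3C2)cc1` gives 67500 nM in this assay.

Among these three, compound 1 has the lowest number, so it is the strongest inhibitor of the set; the nearest is compound 3 and the furthest is compound 2. The next compound, compound 4 `O=C(N/N=C/c1cc(F)c(F)cc1Cl)N1CCc2ncnc(Nc3ccc(F)c(Cl)c3)c2C1`, differs from compound 1 in one place: 2-chloro-4,5-difluorophenyl in place of phenyl on a carbon with a double bond to nitrogen. Among the compounds with values here, two measured steps bear on this change, since both also alter the phenyl on the carbon with a double bond to nitrogen. Adding a nitro group gave a 3.0-fold higher number from compound 1 to compound 2 (0.48 log units; beyond the scatter), and adding a cyano group gave a 2.3-fold higher number from compound 1 to compound 3 (0.37 log units; beyond the scatter); both were modest weakenings. Within the data shown here, the change to compound 4 is of the same kind, a substituted phenyl in place of the bare one, though with halogens rather than nitro or cyano, and the two halogen-bearing steps here offer no direct precedent. The expectation is therefore a small rise or none beyond the scatter in this assay, so compound 4 is estimated at 40000 nM (range 14000 nM to 110000 nM), meaning an expected step of a 1.4-fold higher number from compound 1 to compound 4 (0.14 log units; within the scatter).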

Compound 4, half-maximal inhibitory concentration: 46100 nM
Compound 4: the middle estimate sits 1.2-fold (0.06 log units) below what was measured; measured number inside the range.
By their numbers in this assay, from the lowest: compounds 1, 4, 3 and 2 (each within the scatter of the next, the first and the last beyond it).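

On the carbon with a double bond to nitrogen, 2-chloro-4,5-difluorophenyl in place of phenyl gives a 1.6-fold higher number from compound 1 to compound 4 (0.20 log units; within the scatter) in this assay and so, unlike the nitro and cyano changes, stays within the scatter of the unsubstituted compound. Compound 4 also cannot be separated from the other two substituted compounds, with a 1.5-fold lower number from compound 3 to compound 4 (0.17 log units; within the scatter) and a 1.9-fold lower number from compound 2 to compound 4 (0.28 log units; within the scatter) so this halogen-bearing ring links the two ends of the series instead of extending it. No measurement here gives a reason for these steps.

From the compounds shown here alone, it remains open whether an amine or a carboxylic acid on this phenyl, or a cyclohexyl ring in its place, would give a lower number than compound 1. Going by these compounds, it is also open whether the chlorine or the fluorines alone would give a number like that of compound 4.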